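The source may report more compounds than this note shows. Statements on the series, on what has been measured and on what is new or still open speak of the compounds shown alone.

Working notes on the series around the core of compound 1 `O=S(=O)(/C=C/c1ccc(F)cc1)Cc1ccc(Nc2ncnc3ccccc23)cc1`, read in a functional assay on SW-620 cells (Homo sapiens); a higher number here means a weaker inhibitor of growth, a lower number a stronger inhibitor of growth. Here compound 1 gives 100000 nM. Compound 2 `O=S(=O)(/C=C/c1ccc(Br)cc1)Cc1ccc(Nc2ncnc3ccccc23)cc1` gives > 100000 nM, which is a limit of the assay and not a number. For the measured compounds named here, compound 3 `O=S(=O)(/C=C/c1ccc(Cl)cc1Cl)Cc1ccc(Nc2ncnc3ccccc23)cc1` gives 14000 nM, the lower of the two true numbers so far. The measured gap is a 7.1-fold lower number from compound 1 to compound 3 (0.85 log units; beyond the scatter), and the comparison with the limit reads an at least 7.1-fold lower number from compound 2 to compound 3 (0.85 log units; beyond the scatter).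

Compound 4 `O=S(=O)(/C=C/c1ccc(F)cc1Cl)Cc1ccc(Nc2ncnc3ccccc23)cc1` differs from compound 3 by fluoro in place of chloro on an aromatic carbon, para to a large group, with the chloro group meta to it retained. The bromo-for-fluoro comparison, a number no lower from compound 1 to compound 2 (the limit leaves the size open), has no readable size and gives little guidance. Compound 4 shares its fluoro with compound 1 and one chloro with compound 3, so part of a 7.1-fold lower number from compound 1 to compound 3 (0.85 log units; beyond the scatter) is expected to be lost, giving a modest rise in this assay. The expected change is a 2.1-fold higher number from compound 3 to compound 4 (0.33 log units; beyond the scatter). For compound 4 the estimated value is 30000 nM, with an expected range of 10000 nM to 90000 nM.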

Compound 4, concentration for 50% growth inhibition: 100000 nM
Beside the measured number, compound 4's estimate is 3.3-fold (0.52 log units) below it; measured number above the stated range.
By their numbers in this assay, from the lowest: compound 3; then compounds 1 and 4 (each within the scatter of the next).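

In this assay, for the compounds shown here, the chloro group para to a large group is what separates the series so far: with fluoro in its place, the step reads a 7.1-fold higher number from compound 3 to compound 4 (0.85 log units; beyond the scatter). The other chloro group, meta to that position, shows no effect on its own when fluoro stays in place, with no change at the digits printed from compound 1 to compound 4 (within the scatter), so the gain seen earlier appears only with both chloro groups present. Compound 2 gives > 100000 nM, which is a limit of the assay and not a number. Against that limit the comparison reads a number no higher from compound 2 to compound 4 (the limit leaves the size open), and its size cannot be read: the limit of > 100000 nM in this assay, at which 1 of the 4 values shown sits.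

From the compounds shown here alone, whether the chloro group para to a large group would act alone, as a 4-chlorophenyl without the second chloro, remains open. Also open, going by these compounds, is whether a methyl, methoxy or nitrile group at that place would match chloro when the other chloro group is retained.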